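The compounds below may be only part of what the source reports. "The series", "measured", "known", "first", "only" and "open" are said of these compounds alone.

Compound 3 `Oc1ccccc1-c1cc(-c2cccc(C(F)(F)F)c2)cc(-c2ccccc2O)n1` stands at the edge of what a functional assay on HCT-15 cells (Homo sapiens) for inhibition (a higher number here means a weaker inhibitor, a lower number a stronger inhibitor), can report: compound 3 gives > 50000 nM, a limit of the assay rather than a number. Compound 1 `Oc1ccccc1-c1cc(-c2ccccc2F)cc(-c2ccccc2O)n1` likewise gives only a limit, > 50000 nM. Compound 2 `Oc1ccccc1-c1cc(-c2ccccc2C(F)(F)F)cc(-c2ccccc2O)n1` gives 3970 nM. The measured steps are an at least 12-fold lower number from compound 1 to compound 2 (1.10 log units; beyond the scatter), an at least 12-fold higher number from compound 2 to compound 3 (1.10 log units; beyond the scatter) and a step that the two limits leave unreadable from compound 1 to compound 3; the series is shaped by the limit of > 50000 nM in this assay, at which 2 of the 3 values shown sit. Compound 4 `Oc1ccc(-c2cc(-c3cccc(C(F)(F)F)c3)cc(-c3ccccc3O)n2)cc1` differs from compound 3 by 4-hydroxyphenyl in place of 2-hydroxyphenyl on an aromatic carbon. Among the measured compounds shown here, every measured step concerns the aryl group bearing fluoro or trifluoromethyl; none touches a hydroxyphenyl group, so no measured step bears on this change. For compound 4 the expected step in this assay is a step that the limit leaves unreadable from compound 3 to compound 4, none beyond the scatter. Compound 4 is estimated at 80000 nM, between 15000 nM and 400000 nM, and is expected to return only a limit again.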

Compound 4, half-maximal inhibitory concentration: > 50000 nM
Compound 4: no number, only a limit; the forecaster's own chance of this, stated with the estimate: 75%; the middle value lies beyond the limit too.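

In this assay compound 4 gives > 50000 nM, a limit and not a number, so with compound 3 also only a limit, the step between them cannot be read: the limit of > 50000 nM in this assay, at which 3 of the 4 values shown sit.

The compounds shown leave open how 4-hydroxyphenyl compares with 2-hydroxyphenyl where a readable value exists.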